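The source may hold more compounds than are shown below. What is called first, only, known or untested is meant among the compounds shown, and "the series" means these compounds.

In a functional assay on MCF7 cells (Homo sapiens) for inhibition (on this read-out higher numbers stand for weaker inhibition and lower numbers for stronger inhibition), compound 1 (`Oc1cccc(-c2nc3cc(F)ccc3s2)c1`) gives 570 nM and compound 2 (`Oc1ccc(-c2nc3cc(F)ccc3s2)cc1`) gives 400 nM as its value. These two numbers lie within the usual scatter of each other, so compound 2 cannot be told apart from compound 1. Compound 3 (`Oc1ccc(-c2nc3cc(C(F)(F)F)ccc3s2)cc1`) has trifluoromethyl in place of fluoro on an aromatic carbon and is still to be measured. Going by the values given here, no measured pair shows such a change, so no shift beyond the scatter is expected in this assay here. The estimated step (a 1.1-fold higher number from compound 2 to compound 3 (0.05 log units; within the scatter)) is therefore small. For compound 3 the expected value is 450 nM with an estimated range from 150 nM to 1400 nM in this read-out.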

Compound 3, half-maximal inhibitory concentration: 13800 nM
Beside the measured number, compound 3's estimate is 31-fold (1.49 log units) below it; the whole stated range lies below it.
By their numbers in this assay, from the lowest: compounds 2 and 1 (each within the scatter of the next); then compound 3.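

In this assay, this aromatic carbon of the shared core proves sensitive to what it carries: trifluoromethyl in place of fluoro gives a 35-fold higher number from compound 2 to compound 3 (1.54 log units; beyond the scatter), a large weakening of inhibition. Compound 1 and compound 2 differ only in the place of the hydroxyl and could not show this. No measurement shown bears on the reason for this step.

Still open, as far as these compounds go, is how chloro, methoxy, an amine or plain hydrogen would read at this carbon. Also open, from the compounds shown here alone, is whether the same change would cost as much with the hydroxyl placed as in compound 1.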